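Swapping Benzylsulfanyl for Allyloxy at a Cytotoxicity Limit

The compounds below may be only part of what the source reports. "The series", "measured", "known", "first", "only" and "open" are said of these compounds alone.

Three compounds sharing one core have been examined in an ADME assay on BCBL1 cells (Homo sapiens) for cytotoxicity, with a stated time of 7 days; a higher number here means that more compound is tolerated, a lower number that less compound is tolerated. Compound 1, `CCCNc1nc(N)nc2c1ncn2/C=C1/CC1(CO)CO`, gives in this assay only a limit of > 20000 nM. Compound 2, `CCCCCCOc1nc(N)nc2c1ncn2/C=C1/CC1(CO)CO`, likewise reaches in this assay only the limit > 20000 nM. Compound 3, `Nc1nc(SCc2ccccc2)c2ncn(/C=C3/CC3(CO)CO)c2n1`, also stops at the limit > 20000 nM in this assay. Because all three share (the limit of > 20000 nM in this assay, at which 3 of the 3 values shown sit), the steps between them cannot be sized: a step that the two limits leave unreadable from compound 1 to compound 2, a step that the two limits leave unreadable from compound 1 to compound 3 and a step that the two limits leave unreadable from compound 2 to compound 3 all remain unreadable. Compound 4, `C=CCOc1nc(N)nc2c1ncn2/C=C1/CC1(CO)CO`, is not yet measured. It differs from compound 3 in one place: allyloxy in place of benzylsulfanyl on an aromatic carbon. For the measured compounds named here, no measured step bears on this exchange with a readable size, so the expectation rests only on the fact that every compound so far sits at the same limit. No change beyond the scatter is expected from compound 3 to compound 4, with a step that the limit leaves unreadable from compound 3 to compound 4 as the estimated step. Compound 4 is expected to give 40000 nM in this assay, within a range from 15000 nM to 150000 nM, most likely once more reported only as a limit.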

Compound 4, half-maximal cytotoxic concentration: > 20000 nM
Compound 4 ended at the assay's limit (the forecaster's own chance of this, stated with the estimate: 85%); the middle value is on the limit's open side.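

No step from compound 1, compound 2 or compound 3 to compound 4 can be read, because each value is a limit rather than a number: the limit of > 20000 nM in this assay, at which 4 of the 4 values shown sit.

The compounds shown leave open whether exchanging these groups on the shared core changes the read-out at all.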